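A few compounds are considered here, and "the series" means these few. Any claim that something is new, unique, unknown or untested is made for them only; others in the source may bear on it.

In a functional assay on NCI-H1975 cells (Homo sapiens) for antiproliferative activity, read by MTT assay, with a stated time of 72 h (a higher number here means a weaker inhibitor, a lower number a stronger inhibitor), compound 1 (`COc1cc2ncnc(Nc3cccc(F)c3)c2cc1OCCCCC(=O)Nc1ccc(S(N)(=O)=O)cc1`) gives > 40000 nM, which is a limit of the assay and not a number. Its close relative compound 2 (`COc1cc2ncnc(Nc3ccc(F)cc3)c2cc1OCCCCC(=O)Nc1ccc(S(N)(=O)=O)cc1`), which carries 4-fluorophenyl in place of 3-fluorophenyl, gives > 40000 nM, again a limit. Within the data shown here, the one measured step here is a step that the two limits leave unreadable from compound 1 to compound 2, so it offers no size to carry forward. What the series shows so far is the limit of > 40000 nM in this assay, at which 2 of the 2 values shown sit.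

Compound 3 (`COc1ccc(Nc2ncnc3cc(OC)c(OCCCCC(=O)Nc4ccc(S(N)(=O)=O)cc4)cc23)cc1OC`) keeps the core and the side chain of compound 1 and changes only the aryl group: 3,4-dimethoxyphenyl in place of 3-fluorophenyl on a nitrogen on an aromatic ring. Among the measured compounds shown here, this swap is larger than the fluorine shift between compound 1 and compound 2, and no measured step speaks to a 3,4-dimethoxyphenyl group. With only limits to go on, no step beyond the scatter is expected in this assay, and no direction can be favoured. The expected step is a number no higher from compound 1 to compound 3 (the limit leaves the size open). Compound 3 will most likely report only a limit as well. If a number is obtained, the estimate for compound 3 is 40000 nM, with an expected range from 15000 nM to 80000 nM.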

Compound 3, half-maximal inhibitory concentration: 9230 nM
The estimate for compound 3 lay 4.3-fold (0.64 log units) above the measured number, and the stated range ends above it.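

In this assay, the aryl group on a nitrogen on an aromatic ring proves able to move the read-out: 3,4-dimethoxyphenyl gives an at least 4.3-fold lower number from compound 1 to compound 3 (0.63 log units; beyond the scatter), and the same group gives an at least 4.3-fold lower number from compound 2 to compound 3 (0.63 log units; beyond the scatter). Both steps lie beyond the scatter, and they give this position a readable change where the swap between the two fluorophenyl groups gave none. Compound 3, with its core and side chain shared with compound 1, is the only compound shown that gives a number, so among these compounds the difference rests on the aryl group alone, while the two fluorophenyl compounds stay at the limit of the assay: the limit of > 40000 nM in this assay, at which 2 of the 3 values shown sit.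

As far as these compounds go, how large the two steps really are stays open, as compound 1 and compound 2 give only limits and each step is therefore a lower bound. Also open, from the compounds shown here alone, is whether a single methoxy group on the phenyl ring would be enough or both are needed, and how a hydroxyl group, an amine or a longer alkoxy chain in their place would read in this assay.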